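Sulfonyl substituent variation in a pyridylmethyl urea series

The source may report more compounds than this note shows. Statements on the series, on what has been measured and on what is new or still open speak of the compounds shown alone.

Measured so far:
compound 1 `CNS(=O)(=O)c1ccc(NC(=O)NCc2ccncc2)cc1` – in an assay on isolated protein for activation of Nicotinamide phosphoribosyltransferase (Homo sapiens) (on this read-out lower numbers stand for an effect already at smaller amounts and higher numbers for an effect only at larger amounts of compound), compound 1 gives 3230 nM
compound 2 `O=C(NCc1ccncc1)Nc1ccc(S(=O)(=O)c2cccc(Cl)c2)cc1` – compound 2 gives 69 nM
compound 3 `CN(C1CCCC1)S(=O)(=O)c1ccc(NC(=O)NCc2ccncc2)cc1` – compound 3 gives 123 nM

Compound 3 holds the second highest number of the three; its nearest neighbour is compound 2, with a 1.8-fold higher number from compound 2 to compound 3 (0.25 log units; within the scatter), and its furthest is compound 1, with a 26-fold lower number from compound 1 to compound 3 (1.42 log units; beyond the scatter). Compound 4 `O=C(NCc1ccncc1)Nc1ccc(S(=O)(=O)N2CCc3ccccc3C2)cc1` is the next variant: 1,2,3,4-tetrahydroisoquinolin-2-yl in place of cyclopentyl(methyl)amino on a sulfonyl sulfur. Within the data shown here, two steps bear on it: a 47-fold lower number from compound 1 to compound 2 (1.67 log units; beyond the scatter) and a 26-fold lower number from compound 1 to compound 3 (1.42 log units; beyond the scatter), both large, each replacing a small substituent on the sulfonyl sulfur with a bigger one. Between two such enlarged variants, a 1.8-fold higher number from compound 2 to compound 3 (0.25 log units; within the scatter) stayed within the scatter. Compound 4 keeps an enlarged substituent there, so no step beyond the scatter is expected: a 1.2-fold lower number from compound 3 to compound 4 (0.09 log units; within the scatter). Compound 4 is estimated at 100 nM, range 35 nM to 300 nM.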

Compound 4, half-maximal effective concentration: 142 nM
Estimate against measurement, compound 4: 1.4-fold (0.15 log units) below; low and high end bracket the measured number.
By their numbers in this assay, from the lowest: compounds 2, 3 and 4 (each within the scatter of the next, the first and the last beyond it); then compound 1.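

On the sulfonyl sulfur, 1,2,3,4-tetrahydroisoquinolin-2-yl reads the same as cyclopentyl(methyl)amino in this assay (a 1.2-fold higher number from compound 3 to compound 4 (0.06 log units; within the scatter)), despite the added aromatic ring, and the large step away from methylamino holds (a 23-fold lower number from compound 1 to compound 4 (1.36 log units; beyond the scatter)). Against 3-chlorophenyl, the larger groups now show their first step beyond the scatter, though only a modest one (a 2.1-fold higher number from compound 2 to compound 4 (0.31 log units; beyond the scatter)). No measured evidence accounts for these steps.

Open, as far as these compounds go, is how small a group on the sulfonyl sulfur can be before the number rises towards that of methylamino. Also open, from the compounds shown here alone, is whether a piperidine or morpholine ring there reads the same.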